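The compounds below may be only part of what the source reports. "The series", "measured", "known", "first", "only" and "open" are said of these compounds alone.

Compound 1 `COc1ncc(-c2ccc3c(c2)N(c2ccc(C)cc2)C(=O)CO3)cc1NS(=O)(=O)c1ccc(F)cc1`: 12900 nM
Compound 2 `COc1ncc(-c2ccc3c(c2)N(c2ccc(F)cc2)C(=O)CO3)cc1NS(=O)(=O)c1ccc(F)cc1`: > 40000 nM
Compound 3 `COc1ncc(-c2ccc3c(c2)N(C2CCCCC2)C(=O)CO3)cc1NS(=O)(=O)c1ccc(F)cc1`: > 40000 nM

All three were tested in a functional assay on A-375 cells (Homo sapiens) for antiproliferative activity, read by MTT assay, with a stated time of 72 h; on this read-out lower numbers stand for stronger inhibition and higher numbers for weaker inhibition. The value of compound 2 is a limit, > 40000 nM. The value of compound 3 is also only a limit, > 40000 nM, and compound 3 therefore sits at the limit of > 40000 nM in this assay, at which 2 of the 3 values shown sit.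

Compound 4 `COc1ncc(-c2ccc3c(c2)N(c2ccccc2)C(=O)CO3)cc1NS(=O)(=O)c1ccc(F)cc1` follows from compound 3 by phenyl in place of cyclohexyl on an amide-type nitrogen in a ring. The closest measured change is an at least 3.1-fold higher number from compound 1 to compound 3 (0.49 log units; beyond the scatter), which lies beyond the scatter and favours the aromatic ring. Yet an at least 3.1-fold higher number from compound 1 to compound 2 (0.49 log units; beyond the scatter) is also beyond the scatter, so the aromatic ring alone does not assure a number. a step that the two limits leave unreadable from compound 2 to compound 3 cannot be read. A modest step toward a lower number is therefore expected, though compound 4 may stay at the limit.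

The expected step is an at least 1.6-fold lower number from compound 3 to compound 4 (0.20 log units; that floor lies within the scatter). Compound 4 is estimated at 25000 nM, with a range of 10000 nM to 60000 nM.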

Compound 4, half-maximal inhibitory concentration: 15200 nM
The estimate for compound 4 lay 1.6-fold (0.22 log units) above the measured number; the range from low to high includes it.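

On the amide-type nitrogen in a ring, phenyl gives a readable number where cyclohexyl does not: an at least 2.6-fold lower number from compound 3 to compound 4 (0.42 log units; beyond the scatter). On the aromatic carbon of that phenyl, hydrogen in place of fluoro also matters, an at least 2.6-fold lower number from compound 2 to compound 4 (0.42 log units; beyond the scatter), while hydrogen in place of methyl makes no readable difference, a 1.2-fold higher number from compound 1 to compound 4 (0.07 log units; within the scatter). Compound 2 keeps an aromatic ring on this nitrogen and still stands only at a limit: the limit of > 40000 nM in this assay, at which 2 of the 4 values shown sit.

The step between compound 2 and compound 3 cannot be read. As far as these compounds go, whether an amine or a carboxylic acid on that aromatic carbon would keep a readable number remains open.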